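The source may hold more compounds than are shown below. What is called first, only, known or untested is meant among the compounds shown, and "the series" means these compounds.

Compound 1 `Cc1cc(Sc2ccc(Cl)cc2)c(S(C)(=O)=O)cc1C(=O)N=C(N)N`: 19 nM
Compound 2 `Cc1cc(OC2CCCCC2)c(S(C)(=O)=O)cc1C(=O)N=C(N)N`: 37 nM

Both compounds were tested in a functional assay for inhibition of sodium/hydrogen exchanger (Oryctolagus cuniculus); on this read-out lower numbers stand for stronger inhibition and higher numbers for weaker inhibition. Compound 2 stands at the upper end of the two numbers, but it gets there only by a 1.9-fold higher number from compound 1 to compound 2 (0.29 log units; within the scatter), a step within the scatter, so the two compounds cannot be told apart on these data.

Compound 3 `Cc1cc(Nc2cccc(Cl)c2)c(S(C)(=O)=O)cc1C(=O)N=C(N)N` differs from compound 2 in one place: (3-chlorophenyl)amino in place of cyclohexyloxy on an aromatic carbon. Within the data shown here, the only measured step that bears on this change is the one from compound 1 to compound 2, where a chlorophenyl-bearing group gave way to cyclohexyloxy and the number moved by a 1.9-fold higher number from compound 1 to compound 2 (0.29 log units; within the scatter), within the scatter. Compound 3 brings a chlorophenyl-bearing group back, now joined through an amino group rather than a sulfur, so on this single comparison the expected movement in this assay is small, if anything toward a lower number, and not beyond the scatter. For compound 3 the number is therefore estimated at 25 nM, with a range of 8 nM to 80 nM, an expected step of a 1.5-fold lower number from compound 2 to compound 3 (0.17 log units; within the scatter).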

Compound 3, half-maximal inhibitory concentration: 33 nM
For compound 3 the middle estimate is 1.3-fold (0.12 log units) below the measured one, within the range that was stated.
By their numbers in this assay, from the lowest: compounds 1, 3 and 2 (each within the scatter of the next).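

In this assay the change from cyclohexyloxy to (3-chlorophenyl)amino gives a 1.1-fold lower number from compound 2 to compound 3 (0.05 log units; within the scatter) and so cannot be told from no change, even though a non-aromatic ring gives way to an aromatic one and a hydrogen-bond donor enters on this carbon ortho to the methylsulfonyl group. Replacing (4-chlorophenyl)sulfanyl with (3-chlorophenyl)amino gives a 1.7-fold higher number from compound 1 to compound 3 (0.24 log units; within the scatter) and is also unresolved, so all three groups at this position give numbers within the scatter of one another, though this step alters both the linking atom and the place of the chlorine and cannot separate the two. Nothing measured here accounts for this similarity.

The compounds shown leave open whether the number would hold with a group lacking a ring, such as methoxy or a longer alkyl chain, or with a carboxylic acid or a primary amine at this position. They also leave open what the linking atom and the place of the chlorine each contribute, which a (4-chlorophenyl)amino group could help to separate.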